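Methoxy in place of chloro at the end of the series

The compounds below may be only part of what the source reports. "The series", "measured", "known", "first", "only" and "open" are said of these compounds alone.

In an ADME assay on HEK293 cells (Homo sapiens) for cytotoxicity, read by MTT assay, with a stated time of 72 h (on this read-out higher numbers stand for weaker inhibition and lower numbers for stronger inhibition), compound 3 `O=C(CN1CCN(C(=O)c2cccc(Cl)c2)CC1)N1CCN(CCCc2c[nH]c3ccccc23)CC1` gives 99100 nM, compound 1 `O=C(CN1CCN(C(=O)c2ccc(Br)cc2)CC1)N1CCN(CCCc2c[nH]c3ccccc23)CC1` gives 71900 nM and compound 2 `Cc1ccc(C(=O)N2CCN(CC(=O)N3CCN(CCCc4c[nH]c5ccccc45)CC3)CC2)cc1` gives 159000 nM. Compound 3 stands within the scatter of both others, as shown by a 1.4-fold higher number from compound 1 to compound 3 (0.14 log units; within the scatter) and a 1.6-fold lower number from compound 2 to compound 3 (0.21 log units; within the scatter). Within the data shown here, the one step beyond the scatter is modest: a 2.2-fold higher number from compound 1 to compound 2 (0.34 log units; beyond the scatter). Compound 4 `COc1cccc(C(=O)N2CCN(CC(=O)N3CCN(CCCc4c[nH]c5ccccc45)CC3)CC2)c1` differs from compound 3 by methoxy in place of chloro on an aromatic carbon, with methoxy in place of chloro on an aromatic carbon, meta to a large group. Among the measured compounds shown here, no measured compound carries methoxy, but all three steps at this ring are small, so no step beyond the scatter is expected. The expected step is a 1.2-fold higher number from compound 3 to compound 4 (0.08 log units; within the scatter). Compound 4 is estimated at 120000 nM, with an expected range of 65000 nM to 220000 nM.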

Compound 4, half-maximal inhibitory concentration: 143000 nM
Beside the measured number, compound 4's estimate is 1.2-fold (0.08 log units) below it; the measured number falls inside the stated range.
By their numbers in this assay, from the lowest: compounds 1, 3, 4 and 2 (each within the scatter of the next, the first and the last beyond it).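

In this assay, methoxy in place of chloro, meta to a large group, adds a hydrogen-bond acceptor and still stays within the scatter (a 1.4-fold higher number from compound 3 to compound 4 (0.16 log units; within the scatter)). The 3-methoxyphenyl group also stays within the scatter of the other two aryl groups (a 1.1-fold lower number from compound 2 to compound 4 (0.05 log units; within the scatter)) and (a 2.0-fold higher number from compound 1 to compound 4 (0.30 log units; within the scatter)). No supporting data offer a reason for these steps.

Going by these compounds, whether an amine or a carboxylic acid at this place would give a step beyond the scatter stays open. So does the reading of methoxy elsewhere on this ring.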